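Methyl for chloro on the other aryl ring

The source may report more compounds than this note shows. Statements on the series, on what has been measured and on what is new or still open speak of the compounds shown alone.

Three compounds share one core and differ only in the substituents on their two outer rings. In a functional assay on MCF7 cells (Homo sapiens) for antiproliferative activity, read by MTT assay, with a stated time of 48 h (on this read-out lower numbers stand for stronger inhibition and higher numbers for weaker inhibition), compound 1 `Clc1ccc(NCc2cn(-c3ccccc3)nc2-c2ccc(Cl)cc2)cc1` gives 2280 nM, the lowest of the three numbers, though all three lie within the usual scatter of one another. Compound 2 `Cc1ccc(NCc2cn(-c3ccccc3)nc2-c2ccc(Cl)cc2)cc1` gives 3110 nM in this assay, and compound 3 `Fc1ccc(NCc2cn(-c3ccccc3)nc2-c2ccc(Br)cc2)cc1` gives 3960 nM.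

Compound 4 `Cc1ccc(-c2nn(-c3ccccc3)cc2CNc2ccc(Cl)cc2)cc1` has not yet been measured in this assay. Relative to compound 1 it carries methyl in place of chloro on an aromatic carbon, on a six-membered aromatic ring of carbon only. Going by the values given here, one measured step bears on this: a 1.4-fold higher number from compound 1 to compound 2 (0.13 log units; within the scatter), the same exchange made on the other outer ring. That step stayed within the scatter, and there is no other measured exchange on the ring that changes here. The account therefore expects no shift beyond the scatter in this assay for compound 4, and an expected step of a 1.2-fold higher number from compound 1 to compound 4 (0.09 log units; within the scatter) from compound 1. Compound 4 is estimated at 2800 nM, with a range from 1400 nM to 5600 nM.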

Compound 4, half-maximal inhibitory concentration: 6020 nM
Compound 4: the middle estimate sits 2.2-fold (0.33 log units) below what was measured; the measured number lies above the stated range.
By their numbers in this assay, from the lowest: compounds 1, 2, 3 and 4 (each within the scatter of the next, the first and the last beyond it).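

Going by these compounds alone, exchanging chloro for methyl on this ring, the change from 4-chlorophenyl to 4-methylphenyl, is the first to move the read-out beyond the scatter in this assay: a 2.6-fold higher number from compound 1 to compound 4 (0.42 log units; beyond the scatter). The same exchange on the other outer ring gave only a 1.4-fold higher number from compound 1 to compound 2 (0.13 log units; within the scatter), so at this position, on the evidence of these two steps, the exchange cannot be treated as equivalent to the one on the other ring, and the higher number here stands for weaker inhibition. Nothing available explains why the two rings respond differently to the exchange.

With only chloro and methyl compared at this position, the compounds shown leave open whether the step reflects something particular to methyl or would recur with other groups. How an ethyl chain, a methoxy group, an amine or a carboxylic acid at this place would compare with chloro remains an open question.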